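The source may report more compounds than this note shows. Statements on the series, on what has been measured and on what is new or still open speak of the compounds shown alone.

Measured compounds in an ADME assay on Vero cells (Chlorocebus sabaeus) for cytotoxicity, read by MTT assay; a higher number here means a weaker inhibitor, a lower number a stronger inhibitor:
- compound 1, `C=CCOc1cc(OC)c(C(=O)/C=C/c2ccc(F)cc2)c(OCC=C)c1`: 13600 nM
- compound 2, `C=CCOc1cc(OC)c(C(=O)/C=C/c2ccccc2Br)c(OCC=C)c1`: 13900 nM

Compound 1 holds the lowest of the two numbers, but its nearest neighbour, compound 2, sits at a 1.0-fold higher number from compound 1 to compound 2 (0.01 log units; within the scatter), which is within the scatter, so no order between them can be read.

Compound 3, `C=CCOc1cc(OC)c(C(=O)/C=C/c2ccncc2)c(OCC=C)c1`, has not yet been measured in this assay. Its difference from compound 1 is pyridin-4-yl in place of 4-fluorophenyl on a double-bonded chain carbon bound to a double-bonded chain carbon. Among the measured compounds shown here, the only measured step that bears on this position is the exchange of one aryl group for another on the same chain carbon, a 1.0-fold higher number from compound 1 to compound 2 (0.01 log units; within the scatter), which left the number unchanged within the scatter. For the measured compounds named here, no measured step shows a heteroaryl entering at this place, so the expectation rests on that single aryl exchange alone.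

The expected step is therefore a 1.0-fold lower number from compound 1 to compound 3 (0.02 log units; within the scatter), that is, none beyond the scatter. For compound 3 the estimated value in this assay is 13000 nM, with a range from 6000 nM to 30000 nM.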

Compound 3, half-maximal inhibitory concentration: 2800 nM
Compound 3: middle estimate off by 4.6-fold (0.67 log units), on the high side; measured number below the stated range.
By their numbers in this assay, from the lowest: compound 3; then compounds 1 and 2 (each within the scatter of the next).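

In this assay, the aryl group on this chain carbon turns out to matter: pyridin-4-yl gives a 4.9-fold lower number from compound 1 to compound 3 (0.69 log units; beyond the scatter) and a 5.0-fold lower number from compound 2 to compound 3 (0.70 log units; beyond the scatter), whereas the exchange between the two halophenyl groups gave only a 1.0-fold higher number from compound 1 to compound 2 (0.01 log units; within the scatter). Among the compounds shown here, the one change that moves the number beyond the scatter is therefore the replacement of a carbon-only aromatic ring by a ring with a nitrogen and a hydrogen-bond acceptor, although this reading rests on compound 3 alone. Nothing available explains the shift.

Still open, on these data alone, is whether pyridin-3-yl or pyridin-2-yl would give a step like that of pyridin-4-yl, or whether the ring nitrogen's place counts. Also open, as far as these compounds go, is how an unsubstituted phenyl, or a phenyl carrying a dimethylamino group, would stand against these three compounds.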